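The compounds below may be only part of what the source reports. "The series", "measured", "known", "first", "only" and "open" are said of these compounds alone.

Among the measured compounds shown here, compound 1 `COc1ccc(C2C(C)C(=O)CC(c3ccc(Cl)cc3)N2C(=O)CN2CCN(C)CC2)cc1` gives 53.1% in a functional assay on the whole organism for inhibition, with Mus musculus as the target, in the writhing test, with a stated time of 1 h, at a dose of 60 mg/kg by the oral route (a higher number here means more inhibition at the dose given (going by the name of the read-out), a lower number less inhibition), the lowest of the two numbers so far, with compound 2 `COc1ccc(C2C(C)C(=O)CC(c3ccc(F)cc3)N2C(=O)CN2CCN(C)CC2)cc1` nearest at 55.2%; the step of a number 2.1 percentage points higher from compound 1 to compound 2 (within the scatter) stays within the scatter. Compound 3 `COc1ccc(C2C(C)C(=O)CC(c3ccc(Cl)cc3)N2C(=O)CCl)cc1` differs from compound 1 by chloro in place of 4-methylpiperazin-1-yl on a saturated chain carbon bound to a carbonyl carbon. For the measured compounds named here, the single measured step, from compound 1 to compound 2, concerns a ring substituent and does not bear on this change, so no step size can be read across; the expectation rests on compound 1 alone. Compound 3 is estimated at 42%, range 22% to 62%, a step of a number 11.1 percentage points lower from compound 1 to compound 3 (beyond the scatter) expected.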

Compound 3, a percentage reported as inhibition, in the whole organism at one dose (the size of the read-out at that dose, not a potency): 44.1%
Compound 3: the middle estimate sits 2.1 percentage points below what was measured, and the stated range covers the measured number.
By their numbers in this assay, from the lowest: compounds 3, 1 and 2 (each within the scatter of the next, the first and the last beyond it).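

Chloro in place of 4-methylpiperazin-1-yl on a saturated chain carbon bound to a carbonyl carbon gives a number 9 percentage points lower from compound 1 to compound 3 (within the scatter) in this assay. This large change at the position therefore leaves the reading within the scatter, and inhibition in this test does not depend on the presence of the 4-methylpiperazin-1-yl ring in this pair. No measurement at hand accounts for the step.

Open, on these data alone, is how morpholin-4-yl or dimethylamino would read on the same carbon. Also open, as far as these compounds go, is whether the step holds with fluoro on the aromatic ring, as in compound 2.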